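The source may report more compounds than this note shows. Statements on the series, on what has been measured and on what is new or still open speak of the compounds shown alone.

In an assay (Cricetulus griseus) for inhibition of aldehyde dehydrogenase, mitochondrial (Homo sapiens) (on this read-out lower numbers stand for stronger inhibition and higher numbers for weaker inhibition), compound 3 `CCOC(=O)CCCCOc1ccc2c(=O)c(-c3ccc(O)cc3)coc2c1` gives 240 nM, the highest number among the three measured, though only one gap separating it from the others lies beyond the scatter. Compound 1 `CCOC(=O)COc1ccc2c(=O)c(-c3ccc(O)cc3)coc2c1` gives 130 nM in this assay, and compound 2 `CCOc1ccc2c(=O)c(-c3ccc(O)cc3)coc2c1` gives 80 nM. Compound 4 `O=c1c(-c2ccc(O)cc2)coc2cc(OCCCCCCO)ccc12` has not yet been measured; it differs from compound 3 by 2-hydroxyethyl in place of ethoxycarbonyl on a saturated chain carbon, four bonds along the chain from an oxygen on an aromatic ring. The earlier steps shown here that changed the chain on the same aryl ether oxygen bear on this: a 1.8-fold higher number from compound 1 to compound 3 (0.27 log units; within the scatter), while a 3.0-fold higher number from compound 2 to compound 3 (0.48 log units; beyond the scatter). Given these small moves, the estimated step is a 1.2-fold lower number from compound 3 to compound 4 (0.08 log units; within the scatter), with nothing expected beyond the scatter. Compound 4 is therefore expected to give about 200 nM, within a range from 80 nM to 500 nM.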

Compound 4, half-maximal inhibitory concentration: 120 nM
Beside the measured number, compound 4's estimate is 1.7-fold (0.22 log units) above it, within the range that was stated.
By their numbers in this assay, from the lowest: compounds 2, 4, 1 and 3 (each within the scatter of the next, the first and the last beyond it).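

Replacing the ester end of the long chain with 2-hydroxyethyl keeps the number within the scatter (a 2.0-fold lower number from compound 3 to compound 4 (0.30 log units; within the scatter)). The new information lies in the comparison with the short ethoxy compound: compound 3 stood beyond the scatter from compound 2, but this longer hydroxyl-ended chain does not (a 1.5-fold higher number from compound 2 to compound 4 (0.18 log units; within the scatter)), and it also stays within the scatter of the short ester (a 1.1-fold lower number from compound 1 to compound 4 (0.03 log units; within the scatter)). No measurement available here accounts for this behaviour. Still open, from the compounds shown here alone, is whether a carboxylic acid or an amine at the chain end, or a longer chain, would move the number beyond the scatter.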